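Swapping the benzyl aryl group in a phenoxyethylamine series

A few compounds are considered here, and "the series" means these few. Any claim that something is new, unique, unknown or untested is made for them only; others in the source may bear on it.

Measured compounds:
- compound 1, `COc1cccc(OC)c1OCCNCCOc1ccccc1OCc1ccccc1C`: 7.81
- compound 2, `COc1cccc(OC)c1OCCNCCOc1ccccc1OCc1ccc([N+](=O)[O-])cc1`: 8.58
- compound 3, `COc1ccccc1COc1ccccc1OCCNCCOc1c(OC)cccc1OC`: 8.53

All three share one core and differ only in the aryl group carried on a saturated chain carbon bound to an oxygen on an aromatic ring. In a functional assay on Vas deferens for antagonist activity at Alpha-1A adrenergic receptor (Rattus norvegicus) (a higher number here means a more potent compound, by a factor of ten per unit of this negative logarithm, a lower number a less potent compound), compound 3 stands second highest of the three numbers, next to compound 2, and the pair is separated by a number 0.05 log units lower from compound 2 to compound 3 (within the scatter). Compound 1 sits furthest away, with the step of a number 0.72 log units higher from compound 1 to compound 3 (beyond the scatter).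

Compound 4, `COc1cccc(OC)c1OCCNCCOc1ccccc1OCc1ccc(OC(C)C)cc1`, has not been measured. Its change from compound 3 reads (4-isopropoxyphenyl in place of 2-methoxyphenyl on a saturated chain carbon bound to an oxygen on an aromatic ring). Going by the values given here, two measured steps bear on this position: a number 0.77 log units higher from compound 1 to compound 2 (beyond the scatter) and a number 0.05 log units lower from compound 2 to compound 3 (within the scatter). They show that a 2-methylphenyl group gives a lower number, while a 4-nitrophenyl and a 2-methoxyphenyl group give nearly the same number. Among the compounds with values here, no measured compound carries a 4-isopropoxyphenyl group, so the step is uncertain in both directions. The expected step in this assay is a number 0.13 log units lower from compound 3 to compound 4 (within the scatter), roughly no change beyond the scatter. Compound 4 is therefore estimated at 8.4, between 7.8 and 9.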

Compound 4, negative logarithm of the antagonist equilibrium constant: 8.17
Compound 4: middle estimate off by 0.23 log units, on the high side, within the range that was stated.
By their numbers in this assay, from the lowest: compound 1; then compound 4; then compounds 3 and 2 (each within the scatter of the next).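

In this assay, the 4-isopropoxyphenyl group gives a level of its own at this position: a number 0.36 log units lower from compound 3 to compound 4 (beyond the scatter), a number 0.41 log units lower from compound 2 to compound 4 (beyond the scatter), and a number 0.36 log units higher from compound 1 to compound 4 (beyond the scatter). The aryl groups therefore no longer fall into one low compound and a matched higher pair, since compound 4 stands apart from all three. Nothing measured here explains the size of these steps.

The step to compound 4 changes both the alkoxy group and its place on the ring, so a 4-methoxyphenyl group would be needed to separate those two changes. Going by these compounds, how a 4-aminophenyl or 4-carboxyphenyl group would compare also remains open.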